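The source may report more compounds than this note shows. Statements on the series, on what has been measured and on what is new or still open speak of the compounds shown alone.

Values in a functional assay on K562 cells (Homo sapiens) for cytotoxicity, read by MTT assay, with a stated time of 5 days; a higher number here means a weaker inhibitor, a lower number a stronger inhibitor:

compound 1 `COc1ccc(Cn2cc(-c3cc(OC)c(OC)c(OC)c3)nn2)cc1[N+](=O)[O-]`: a limit, > 10000 nM
compound 2 `COc1ccc(Cn2cc(-c3cc(OC)c(OC)c(OC)c3)nn2)cc1N`: a limit, > 10000 nM
compound 3 `COc1ccc(-c2cn(Cc3cc(OC)c(OC)c(OC)c3)nn2)cc1N`: a limit, > 10000 nM

Compound 2 and compound 1 share a core and differ by nitro in place of amino on an aromatic carbon; the step that the two limits leave unreadable from compound 2 to compound 1 cannot be read, since both values are limits. Compound 3 has the same atoms as compound 2 joined differently; the difference between the two cores is not broken down here.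

Compound 4 `COc1ccc(-c2cn(Cc3cc(OC)c(OC)c(OC)c3)nn2)cc1[N+](=O)[O-]` is not yet measured. It differs from compound 3 by nitro in place of amino on an aromatic carbon, the same change as from compound 2 to compound 1, at a place described in the same words.

For compound 4 in this assay the expected value is 15000 nM, with 5000 nM to 60000 nM as the range. The expected step that the limit leaves unreadable from compound 3 to compound 4 is set near zero because the measured values of this series sit only at the limit of > 10000 nM in this assay, at which 3 of the 3 values shown sit. A limit rather than a number is the expected outcome for compound 4.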

Compound 4, half-maximal inhibitory concentration: > 10000 nM
Compound 4 was reported as a limit (the forecaster's own chance of this, stated with the estimate: 85%); the middle value does not contradict the limit.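

The step from compound 3 to compound 4 cannot be read, as both values are limits: the limit of > 10000 nM in this assay, at which 4 of the 4 values shown sit.

The compounds shown leave open whether nitro in place of amino alters the result on either core in this assay.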